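Methyl on the phenyl ring of a bis-indolyl quinone

This account rests on a few compounds, and the source may have more. Where it says the series, first, only, none or still open, it means among the compounds named here.

Measured compounds:
compound 1 `Cc1ccc(-c2[nH]c3ccccc3c2C2=C(Br)C(=O)C(Br)=C(Br)C2=O)cc1`, 21.6 ug/mL
compound 2 `Cc1[nH]c2ccccc2c1C1=C(Cl)C(=O)C(Cl)=C(c2c(-c3ccccc3)[nH]c3ccccc23)C1=O`, 5.27 ug/mL

In a functional assay on MDA-MB-231 cells (Homo sapiens) for antiproliferative activity, read by CCK-8 assay, with a stated time of 48 h (on this read-out higher numbers stand for weaker inhibition and lower numbers for stronger inhibition), compound 2 gives 5.27 ug/mL, the lower of the two numbers shown, and the gap to compound 1 lies beyond the scatter. Compound 3 `Cc1ccc(-c2[nH]c3ccccc3c2C2=C(Cl)C(=O)C(Cl)=C(c3c(C)[nH]c4ccccc34)C2=O)cc1` differs from compound 2 by methyl in place of hydrogen on an aromatic carbon, a methyl in place of hydrogen on an aromatic carbon. Within the data shown here, no measured pair shows this change alone, so the step is expected to be small: no more than the scatter, in either direction. Compound 3 is therefore estimated at 5.5 ug/mL, within 2.5 ug/mL to 12 ug/mL, which means an expected step of a 1.0-fold higher number from compound 2 to compound 3 (0.02 log units; within the scatter).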

Compound 3, half-maximal inhibitory concentration: 5.77 ug/mL
Beside the measured number, compound 3's estimate is 1.0-fold (0.02 log units) below it; low and high end bracket the measured number.
By their numbers in this assay, from the lowest: compounds 2 and 3 (each within the scatter of the next); then compound 1.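

In this assay, the change from phenyl to 4-methylphenyl, a methyl in place of hydrogen on an aromatic carbon para to a large group, gives a 1.1-fold higher number from compound 2 to compound 3 (0.04 log units; within the scatter) and so stays within the scatter. This is the first pair shown that differs in one place, and it shows that this position takes a methyl without a measurable shift in this read-out. Nothing at hand gives a reason for this result.

Still open, as far as these compounds go, is how an amine, a carboxylic acid or a longer chain would read at this position.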